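The compounds below may be only part of what the source reports. "The series", "measured", "known", "first", "only" and "open" are said of these compounds alone.

Working notes on the series. In a functional assay on HeLa cells (Homo sapiens) for inhibition, read by trypan blue exclusion, with a stated time of 72 h (a higher number here means a weaker inhibitor of growth, a lower number a stronger inhibitor of growth), compound 1 `CC/C(=C(\c1ccccc1)c1ccc(NC(=O)C(C)C)cc1)c1ccccc1` gives > 30000 nM, which is a limit of the assay and not a number. Compound 1 therefore stands at the limit of > 30000 nM in this assay, at which 1 of the 3 values shown sits.

Compound 2 `CC/C(=C(\c1ccccc1)c1ccc(NC(=O)C(C)C)cc1)c1ccc(OCc2ccccc2)cc1` gives 10200 nM, and compound 3 `CC/C(=C(\c1ccccc1)c1ccc(NC(=O)C(C)C)cc1)c1ccc(Cl)cc1Cl` gives 3300 nM. Two measured steps start from compound 1: benzyloxy in place of hydrogen gave an at least 2.9-fold lower number from compound 1 to compound 2 (0.46 log units; beyond the scatter), and 2,4-dichlorophenyl in place of phenyl gave an at least 9.0-fold lower number from compound 1 to compound 3 (0.95 log units; beyond the scatter). Both are bounds rather than exact sizes.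

Compound 4 `CC/C(=C(\c1ccc(O)cc1)c1ccc(NC(=O)C(C)C)cc1)c1ccccc1` has hydroxy in place of hydrogen on an aromatic carbon, para to a large group: hydroxy in place of hydrogen on an aromatic carbon. Neither measured step alters the ring that takes this hydroxy, so they bear on it only loosely. For the measured compounds named here, both lowered the number, so a modest downward step is expected in this assay, closer to the one seen for compound 2 than to the one seen for compound 3. The expected change is an at least 3.0-fold lower number from compound 1 to compound 4 (0.47 log units; beyond the scatter). Compound 4 is estimated at 10000 nM, with an expected range of 3000 nM to 30000 nM.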

Compound 4, concentration for 50% growth inhibition: 9900 nM
Estimate against measurement, compound 4: 1.0-fold (0.00 log units) above; low and high end bracket the measured number.
By their numbers in this assay, from the lowest: compound 3; then compounds 4 and 2 (each within the scatter of the next). At a limit, above all of these: compound 1.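

For the compounds shown here, compound 4 gives the first reading on this ring of the core: in this assay, the change from phenyl to 4-hydroxyphenyl gives an at least 3.0-fold lower number from compound 1 to compound 4 (0.48 log units; beyond the scatter). The earlier steps shown here changed only the other ring, so this shows that a step beyond the scatter can also come from this ring, and that a single added oxygen atom is enough to produce it. The true size of the step remains unknown because the starting value is a limit of the assay and not a number: the limit of > 30000 nM in this assay, at which 1 of the 4 values shown sits.

Open, going by these compounds, is whether a methoxy group or an amine, para to a large group on the same ring, would give a similar step. Also open, on these data alone, is how hydroxy on this ring would behave together with the 2,4-dichlorophenyl change on the other ring.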